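The source may hold more compounds than are shown below. What is called first, only, known or untested is meant among the compounds shown, and "the series" means these compounds.

Compound 1 `O=C(Nc1ccccc1C(F)(F)F)C1CCc2ccccc2N1C(=O)c1cccc(Cl)c1` gives 754 nM.
Compound 2 `O=C(Nc1ccccc1O)C1CCc2ccccc2N1C(=O)c1cccc(Cl)c1` gives 11000 nM.
Compound 3 `O=C(Nc1cc(C(F)(F)F)cc(C(F)(F)F)c1)C1CCc2ccccc2N1` gives 8760 nM.

In a functional assay on NUGC-3 cells (Homo sapiens) for cytotoxicity, read by sulforhodamine B assay, with a stated time of 72 h (on this read-out higher numbers stand for weaker inhibition of growth and lower numbers for stronger inhibition of growth), compound 1 holds the lowest number of the three. Among the measured compounds shown here, the only single-point step measured, a 15-fold higher number from compound 1 to compound 2 (1.16 log units; beyond the scatter), concerns the anilide side of the shared core and not the acyl group. For the measured compounds named here, compound 3, which carries no acyl group at all and a different anilide, is not a single-change partner of compound 1, so its value shows only that a compound without the (3-chlorophenyl)carbonyl sits well above compound 1.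

Compound 4 `CCC(=O)N1c2ccccc2CCC1C(=O)Nc1ccccc1C(F)(F)F` differs from compound 1 by ethyl in place of 3-chlorophenyl on a carbonyl carbon. Going by the values given here, no measured step bears directly on this change. Compound 4 is therefore expected to give a modestly higher number, a step of a 4.0-fold higher number from compound 1 to compound 4 (0.60 log units; beyond the scatter), with the estimate 3000 nM and a range from 800 nM to 12000 nM.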

Compound 4, concentration for 50% growth inhibition: > 80000 nM
Compound 4 gave a limit, no number; the forecaster's own chance of this, stated with the estimate: 5%; at least 26-fold (1.42 log units) between middle value and limit.
By their numbers in this assay, from the lowest: compound 1; then compounds 3 and 2 (each within the scatter of the next). At a limit, above all of these: compound 4.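

On the acyl side of the shared core, the change from (3-chlorophenyl)carbonyl to propanoyl gives an at least 100-fold higher number from compound 1 to compound 4 (2.02 log units; beyond the scatter). The earlier compounds shown here offered only a step on the anilide side, so this shows that the acyl group also matters strongly for growth inhibition in this assay. Compound 4 gave only a limit, not a number: the limit of > 80000 nM in this assay, at which 1 of the 4 values shown sits.

The compounds shown do not separate the loss of the chlorine from the loss of the aromatic ring. On these data alone, an unsubstituted benzoyl group or a longer chain such as hexanoyl at this carbonyl remains open.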